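The source may hold more compounds than are shown below. What is called first, only, known or untested is meant among the compounds shown, and "the series" means these compounds.

Among the measured compounds shown here, in an assay on cells for displacement of a labelled ligand from Glucagon receptor (Homo sapiens), in the presence of a further agent that is not named here (on this read-out lower numbers stand for stronger inhibition and higher numbers for weaker inhibition), compound 3 `O=C(O)CCNC(=O)c1ccc(C(Oc2ccc(-n3cc(C(F)(F)F)cn3)cc2)C2CCCC2)cc1` gives 420 nM, the lowest number among the three compounds measured so far. Compound 1 `O=C(O)CCNC(=O)c1ccc(C(Oc2ccc(-n3cc(C(F)(F)F)cn3)cc2)C2CC2)cc1` gives 1300 nM and compound 2 `CCC(Oc1ccc(-n2cc(C(F)(F)F)cn2)cc1)c1ccc(C(=O)NCCC(=O)O)cc1` gives 1400 nM; these two lie within the scatter of each other, with a 1.1-fold higher number from compound 1 to compound 2 (0.03 log units; within the scatter). Compound 3 stands apart from both, as a 3.1-fold lower number from compound 1 to compound 3 (0.49 log units; beyond the scatter) and a 3.3-fold lower number from compound 2 to compound 3 (0.52 log units; beyond the scatter), each a modest step but beyond the scatter.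

Compound 4 `CC(C)CC(Oc1ccc(-n2cc(C(F)(F)F)cn2)cc1)c1ccc(C(=O)NCCC(=O)O)cc1` has not yet been measured in this assay. It differs from compound 3 in one place: isobutyl in place of cyclopentyl on a saturated chain carbon bound to an aromatic carbon and an oxygen on an aromatic ring. The measured steps that bear on this change are the two that lead to compound 3, from cyclopropyl and from ethyl to cyclopentyl, both of which lowered the number by a modest step. Isobutyl carries more carbons than ethyl and fewer than cyclopentyl, and it has no ring. For the measured compounds named here, the data contain no step from a ring to an open chain of this size, so the direction is only inferred: a small rise in the number relative to compound 3 is expected, probably within or just beyond the scatter, while staying below compound 2. The expected step is a 1.7-fold higher number from compound 3 to compound 4 (0.22 log units; within the scatter). Compound 4 is estimated at 700 nM, with a range of 300 nM to 1600 nM.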

Compound 4, inhibition constant: 549 nM
Estimate against measurement, compound 4: 1.3-fold (0.11 log units) above; low and high end bracket the measured number.
By their numbers in this assay, from the lowest: compounds 3 and 4 (each within the scatter of the next); then compounds 1 and 2 (each within the scatter of the next).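

In this assay, the open-chain isobutyl group serves this position, a saturated chain carbon bound to an aromatic carbon and an oxygen on an aromatic ring, about as well as the cyclopentyl ring, with a 1.3-fold higher number from compound 3 to compound 4 (0.12 log units; within the scatter), so the ring itself is not needed to keep the number in this range. The advantage over the two smaller groups also persists without a ring, with a 2.6-fold lower number from compound 2 to compound 4 (0.41 log units; beyond the scatter) for the change from ethyl to isobutyl and a 2.4-fold lower number from compound 1 to compound 4 (0.37 log units; beyond the scatter) for the change from cyclopropyl to isobutyl, and among these four compounds cyclopentyl and isobutyl stand together below ethyl and cyclopropyl, with none going against that split. No measurement at hand explains these differences.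

As far as these compounds go, whether a larger ring such as cyclohexyl, a phenyl group or a longer alkyl chain would lower the number further remains open, so the limit of this trend is unknown. From the compounds shown here alone, it is also open how a group carrying a heteroatom, such as an ether or an amine, would behave at this carbon.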